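Moving the chlorine on the amide aryl across two cores

This account rests on a few compounds, and the source may have more. Where it says the series, first, only, none or still open, it means among the compounds named here.

Compound 1 `Cc1noc(C)c1-c1cnc(N)c(Oc2ccc(C(=O)Nc3ccc(Cl)cc3)cc2)n1` and compound 2 `Cc1noc(C)c1-c1cnc(N)c(Oc2ccc(C(=O)Nc3cccc(Cl)c3)cc2)n1` carry one core, while compound 3 `Cn1cc(-c2cnc(N)c(Oc3ccc(C(=O)Nc4ccc(Cl)cc4)cc3)n2)cn1` and compound 4 `Cn1cc(-c2cnc(N)c(Oc3ccc(C(=O)Nc4cccc(Cl)c4)cc3)n2)cn1` carry another. The counted difference between the two cores is 1-methyl-1H-pyrazol-4-yl in place of 3,5-dimethyl-1,2-oxazol-4-yl on an aromatic carbon. In a functional assay on HepG2 cells (Homo sapiens) for inhibition, read by MTT assay, with a stated time of 72 h (on this read-out lower numbers stand for stronger inhibition and higher numbers for weaker inhibition), compound 1 gives 14400 nM, compound 2 gives 7300 nM, and compound 3 gives 11900 nM. The change from compound 1 to compound 2 is 3-chlorophenyl in place of 4-chlorophenyl on an amide-type nitrogen, and it made a 2.0-fold lower number from compound 1 to compound 2 (0.30 log units; within the scatter). The change of core made a 1.2-fold lower number from compound 1 to compound 3 (0.08 log units; within the scatter). Compound 4 differs from compound 3 by 3-chlorophenyl in place of 4-chlorophenyl on an amide-type nitrogen; the place of the change reads the same in both pairs, so this is the same change, seen twice among these compounds. Compound 4 has not yet been measured in this assay. For the measured compounds named here, the step from compound 3 to compound 4 is expected to be about a 1.8-fold lower number from compound 3 to compound 4 (0.26 log units; within the scatter), set beside the earlier one, and this rests on the single measured instance of the change, a 2.0-fold lower number from compound 1 to compound 2 (0.30 log units; within the scatter), with no second instance to test it. Compound 4 is estimated at 6500 nM, expected to lie between 3000 nM and 14000 nM.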

Compound 4, half-maximal inhibitory concentration: 21200 nM
Beside the measured number, compound 4's estimate is 3.3-fold (0.51 log units) below it; the measured number lies above the stated range.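

In this assay, the same chlorine move that was tested on the core of compound 1 gave a 1.8-fold higher number from compound 3 to compound 4 (0.25 log units; within the scatter), so its result did not carry over to the core of compound 3, even though each step alone lies within the scatter: the same change on two cores in this assay, a 2.0-fold lower number (0.30 log units; within the scatter) from compound 1 to compound 2 and a 1.8-fold higher number (0.25 log units; within the scatter) from compound 3 to compound 4, 3.5-fold (0.55 log units) apart, beyond the scatter of two such steps. Read the other way, the change of core gave a 2.9-fold higher number from compound 2 to compound 4 (0.46 log units; beyond the scatter), whereas it stayed within the scatter on the 4-chlorophenyl compounds, so in these four compounds the two changes do not add up independently: the same change on two cores in this assay, a 1.2-fold lower number (0.08 log units; within the scatter) from compound 1 to compound 3 and a 2.9-fold higher number (0.46 log units; beyond the scatter) from compound 2 to compound 4, 3.5-fold (0.55 log units) apart, beyond the scatter of two such steps. For the compounds shown here, this shows that a step measured on one of these cores was a poor guide to the other, but with only one pair on each core it does not show what sets the two apart or how either change would behave on a further core.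

On these data alone, it remains open whether the two steps would still part with a fluorine or a methoxy group in place of the chlorine on the amide aryl. Also open, as far as these compounds go, is what a plain phenyl in place of 1-methyl-1H-pyrazol-4-yl would do to the chlorine step.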